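A few compounds are considered here, and "the series" means these few. Any claim that something is new, unique, unknown or untested is made for them only; others in the source may bear on it.

Measured in a functional assay on K-562R cells (Homo sapiens) for cytotoxicity, read by MTT assay, with a stated time of 48 h; on this read-out higher numbers stand for weaker inhibition and lower numbers for stronger inhibition:
- compound 1 `COc1ccc(-c2c[nH]c(=O)n2-c2cc(OC)c(OC)c(OC)c2)cc1[N+](=O)[O-]`: > 50000 nM (a limit of the assay)
- compound 2 `COc1ccc(-c2cn(C(=O)Nc3cc(OC)c(OC)c(OC)c3)c(=O)n2-c2cc(OC)c(OC)c(OC)c2)cc1`: 3500 nM

For the measured compounds named here, compound 2, at 3500 nM, holds the only actual number in this small set. Compound 1 gives > 50000 nM, which is a limit and not a number.

The next compound to be tested is compound 3 `COc1ccc(-c2cn(C(=O)Nc3cc(OC)c(OC)c(OC)c3)c(=O)n2-c2cc(OC)c(OC)c(OC)c2)cc1N`. It differs from compound 2 by one change: amino in place of hydrogen on an aromatic carbon. This places amino in place of hydrogen on an aromatic carbon, ortho to a methoxy group, so the 4-methoxyphenyl becomes 3-amino-4-methoxyphenyl. The rest of the structure stays as in compound 2.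

Going by the values given here, no measured pair in the set differs in one place only, so the data give no direct size for this change. In this assay a moderate step toward stronger inhibition is expected, though a result within the scatter of compound 2 would not be surprising. The expected change is a 2.9-fold lower number from compound 2 to compound 3 (0.46 log units; beyond the scatter). For compound 3 the estimated value is 1200 nM, with an expected range of 150 nM to 7000 nM.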

Compound 3, half-maximal inhibitory concentration: 9400 nM
Compound 3: the middle estimate sits 7.8-fold (0.89 log units) below what was measured; measured number outside the range, above it.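

For the compounds shown here, the change from 4-methoxyphenyl to 3-amino-4-methoxyphenyl provides the first comparison that differs in one place only: in this assay there is a 2.7-fold higher number from compound 2 to compound 3 (0.43 log units; beyond the scatter). On this aromatic carbon, ortho to a methoxy group, amino in place of hydrogen therefore goes with modestly weaker inhibition, yet the read-out remains an actual number and not a limit, with compound 3 at 9400 nM. Nothing in the data shown accounts for the direction or size of this step.

Going by these compounds, whether this step is specific to amino or would also appear with other groups on the same carbon remains open; a hydroxyl, an acetamide or a dimethylamino group there would help to separate those cases. This single step also leaves open whether amino would have the same effect on a compound with a different group in place of the trimethoxyphenyl carboxamide, such as a shorter alkyl amide, so no trend can yet be drawn for this position.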